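This account rests on a few compounds, and the source may have more. Where it says the series, first, only, none or still open, it means among the compounds named here.

Three esters built on one shared core were tested in a functional assay on PA-1 cells (Homo sapiens) for cytotoxicity, read by MTT assay, with a stated time of 4 h; a lower number here means a stronger inhibitor, a higher number a weaker inhibitor. Compound 1 `COC(=O)C1=CO[C@@H](O[C@@H]2O[C@H](CO)[C@@H](OC(C)=O)[C@H](OC(C)=O)[C@H]2OC(C)=O)[C@@H]2[C@@H](C)[C@@H](OC(C)=O)C[C@H]12` was reported as "not active" (no number reported), with no number given. Compound 2 `CCC(=O)OC[C@H]1O[C@@H](O[C@@H]2OC=C(C(=O)OC)[C@H]3C[C@H](OC(C)=O)[C@H](C)[C@@H]23)[C@H](OC(C)=O)[C@@H](OC(C)=O)[C@@H]1OC(C)=O` gives 1.24 ug/mL, and compound 3 `CCCCCCCCCCCCCC(=O)OC[C@H]1O[C@@H](O[C@@H]2OC=C(C(=O)OC)[C@H]3C[C@H](OC(C)=O)[C@H](C)[C@@H]23)[C@H](OC(C)=O)[C@@H](OC(C)=O)[C@@H]1OC(C)=O` gives 6.5 ug/mL. Of the two compounds with a number, compound 2 has the lower one and so is the stronger inhibitor of that pair; compound 1 stands apart without a number. Compound 4 `COC(=O)C1=CO[C@@H](O[C@@H]2O[C@H](COC(=O)C=C(C)C)[C@@H](OC(C)=O)[C@H](OC(C)=O)[C@H]2OC(C)=O)[C@@H]2[C@@H](C)[C@@H](OC(C)=O)C[C@H]12` has not yet been measured. It differs from compound 2 in one place: 2-methylprop-1-en-1-yl in place of ethyl on a carbonyl carbon. Among the compounds with values here, the only measured step that bears on this change is the one at the same carbonyl carbon leading to compound 3, where a far longer chain enters and the number rises a 5.2-fold higher number from compound 2 to compound 3 (0.72 log units; beyond the scatter). The change to compound 4 adds only two carbon atoms and one double bond, so a step smaller than that one is expected, if anything toward a higher number, and possibly within the scatter. Compound 4 is therefore estimated at 2 ug/mL in this assay, within 0.8 ug/mL to 5 ug/mL. That estimate amounts to an expected step of a 1.6-fold higher number from compound 2 to compound 4 (0.21 log units; within the scatter).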

Compound 4, half-maximal inhibitory concentration: 0.65 ug/mL
Compound 4: the middle estimate sits 3.1-fold (0.49 log units) above what was measured; the whole stated range lies above it.
By their numbers in this assay, from the lowest: compounds 4 and 2 (each within the scatter of the next); then compound 3.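

In this assay, 2-methylprop-1-en-1-yl in place of ethyl on this carbonyl carbon gives a 1.9-fold lower number from compound 2 to compound 4 (0.28 log units; within the scatter), so the two compounds cannot be told apart. The earlier step at the same carbonyl carbon, where a far longer chain enters, gave a 5.2-fold higher number from compound 2 to compound 3 (0.72 log units; beyond the scatter), and that alone might suggest that any larger group here raises the number; compound 4 shows that a group with more carbon atoms and a double bond can enter without a step beyond the scatter. Nothing shown here gives a measured reason for either result.

A hexyl chain in place of ethyl on this carbonyl carbon would help show how long the group must become before the number rises. Saturated 2-methylpropyl there would separate the effect of the double bond from that of the added carbon atoms, while an amine or a carboxylic acid on the chain would test a quite different kind of group.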